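Pyrrolidin-1-yl against piperidin-1-yl, taken twice

This account rests on a few compounds, and the source may have more. Where it says the series, first, only, none or still open, it means among the compounds named here.

Measured so far:
Compound 1 `COc1cc2c(Oc3ccc(NC(=O)c4nnn(-c5ccccc5)c4C)cc3F)ccnc2cc1OCCCN1CCCC1`: in a functional assay on U-87MG ATCC cells (Homo sapiens) for cytotoxicity, read by MTT assay, with a stated time of 72 h (a lower number here means a stronger inhibitor, a higher number a weaker inhibitor), compound 1 gives 1000 nM.
Compound 2 `COc1cc2c(Oc3ccc(NC(=O)c4nnn(-c5ccc(F)cc5)c4C(F)(F)F)cc3F)ccnc2cc1OCCCN1CCCC1`: in this assay compound 2 gives 850 nM.
Compound 3 `COc1cc2c(Oc3ccc(NC(=O)c4nnn(-c5ccccc5)c4C)cc3F)ccnc2cc1OCCCN1CCCCC1`: in this assay compound 3 gives 1130 nM.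

One change is made twice in the series: piperidin-1-yl in place of pyrrolidin-1-yl on a saturated chain carbon, three bonds along the chain from an oxygen on an aromatic ring. Measured once, it gives a 1.1-fold higher number from compound 1 to compound 3 (0.05 log units; within the scatter), so compound 1 and compound 3 cannot be told apart in this assay. Compound 2 and compound 4 `COc1cc2c(Oc3ccc(NC(=O)c4nnn(-c5ccc(F)cc5)c4C(F)(F)F)cc3F)ccnc2cc1OCCCN1CCCCC1` share a core that is not that of compound 1 and compound 3; the difference between the two cores is not broken down here. Compound 4 is not yet measured. It stands to compound 2 exactly as compound 3 stands to compound 1: piperidin-1-yl in place of pyrrolidin-1-yl on a saturated chain carbon, three bonds along the chain from an oxygen on an aromatic ring, the same change at the same place, in the same words.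

The expectation for compound 4 rests only on that one measured step. For compound 4 the estimated value is 950 nM, with an expected range of 500 nM to 1800 nM. This means an expected step of a 1.1-fold higher number from compound 2 to compound 4 (0.05 log units; within the scatter), sized this way because a 1.1-fold higher number from compound 1 to compound 3 (0.05 log units; within the scatter).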

Compound 4, half-maximal inhibitory concentration: 1100 nM
Estimate against measurement, compound 4: 1.2-fold (0.06 log units) below; low and high end bracket the measured number.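

In this assay, piperidin-1-yl in place of pyrrolidin-1-yl gives a 1.3-fold higher number from compound 2 to compound 4 (0.11 log units; within the scatter), so this pair cannot be told apart. The change therefore carries from one core to the other as a step too small to resolve, and the two steps do not differ: the same change on two cores in this assay, a 1.1-fold higher number (0.05 log units; within the scatter) from compound 1 to compound 3 and a 1.3-fold higher number (0.11 log units; within the scatter) from compound 2 to compound 4, 1.1-fold (0.06 log units) apart, within the scatter of two such steps. This shows that on these two cores the swap of pyrrolidin-1-yl for piperidin-1-yl leaves no readable mark in this cytotoxicity read-out, but it does not show that the two steps are truly equal, that the same would hold on a third core, or that it would hold in any other read-out.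

The compounds shown leave open whether other amines at the same place on the chain, such as morpholin-4-yl, 4-methylpiperazin-1-yl or dimethylamino, would also give steps within the scatter. Also open, going by these compounds, is whether a longer chain than 3-(piperidin-1-yl)propyl would leave the values where they stand.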